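Notes on amide aryl variation, antiproliferative series

The source may report more compounds than this note shows. Statements on the series, on what has been measured and on what is new or still open speak of the compounds shown alone.

Measured so far:
compound 1 `O=C(Nc1ccc(Cl)c(-c2nnc3c(Cl)cccn23)c1)c1cccnc1` gives > 100000 nM in a functional assay on AN3-CA cells (Homo sapiens) for antiproliferative activity, read by MTT assay, with a stated time of 72 h (on this read-out lower numbers stand for stronger inhibition and higher numbers for weaker inhibition), a limit of the assay.
compound 2 `O=C(Nc1ccc(Cl)c(-c2nnc3c(Cl)cccn23)c1)c1ccc(Cl)cc1Cl` gives 84800 nM in this assay.
compound 3 `O=C(Nc1ccc(Cl)c(-c2nnc3c(Cl)cccn23)c1)c1c(F)cccc1Cl` gives > 100000 nM in this assay, a limit of the assay.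

Compound 3 stands at the limit, where two of the three values sit (the limit of > 100000 nM in this assay, at which 2 of the 3 values shown sit). The change to compound 4 `O=C(Nc1ccc(Cl)c(-c2nnc3c(Cl)cccn23)c1)c1cccnc1Cl` is 2-chloropyridin-3-yl in place of 2-chloro-6-fluorophenyl on a carbonyl carbon. Of the measured steps, a step that the two limits leave unreadable from compound 1 to compound 3 leaves the size unreadable, and an at least 1.1-fold higher number from compound 2 to compound 3 (0.07 log units; that floor lies within the scatter) is only a floor within the scatter. Compound 1, carrying the pyridin-3-yl amide, also sits at the limit. No step beyond the scatter in this assay is therefore expected. Compound 4 is estimated at 150000 nM (range 50000 nM to 500000 nM), most likely again reported as a limit. The expected step that the limit leaves unreadable from compound 3 to compound 4 is essentially none.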

Compound 4, half-maximal inhibitory concentration: > 100000 nM
Compound 4: only a limit was reported; the forecaster's own chance of this, stated with the estimate: 70%; the middle value is on the limit's open side.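

With 2-chloropyridin-3-yl on the carbonyl carbon, compound 4 is also a limit in this assay, so chloro in place of hydrogen on an aromatic carbon of compound 1 gives no readable value: the limit of > 100000 nM in this assay, at which 3 of the 4 values shown sit. Within the data shown here, the only readable comparison is an at least 1.1-fold higher number from compound 2 to compound 4 (0.07 log units; that floor lies within the scatter), and it separates nothing. The steps from compound 1 and compound 3 to compound 4 cannot be read.

From the compounds shown here alone, whether any amide aryl group gives a value clearly inside the assay's range stays open. So does the outcome for an aryl ring carrying an amine or a carboxylic acid.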